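Removing a fluorophenyl from a ring amide nitrogen

The source may hold more compounds than are shown below. What is called first, only, known or untested is meant among the compounds shown, and "the series" means these compounds.

Compound 1 `O=C1COc2ccc(-c3cnc(Cl)c(NS(=O)(=O)c4ccc(F)cc4)c3)cc2N1c1ccc(F)cc1`: in a functional assay on HeLa cells (Homo sapiens) for antiproliferative activity, read by MTT assay, with a stated time of 72 h (a higher number here means a weaker inhibitor, a lower number a stronger inhibitor), compound 1 gives > 40000 nM, which is a limit of the assay, not a number (the limit of > 40000 nM in this assay, at which 1 of the 3 values shown sits).
Compound 2 `O=C1COc2ccc(-c3cnc(Cl)c(NS(=O)(=O)c4ccc(F)cc4)c3)cc2N1`: in this assay compound 2 gives 15600 nM.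
Compound 3 `O=C1COc2ccc(-c3cnc4ccccc4c3)cc2N1c1ccc(F)cc1`: in this assay compound 3 gives 38800 nM.

Compound 1 and compound 2 share a core and differ in one place: hydrogen in place of 4-fluorophenyl on an amide-type nitrogen in a ring. That change brought an at least 2.5-fold lower number from compound 1 to compound 2 (0.40 log units; beyond the scatter). Compound 3 carries a different core; how the cores of compound 1 and compound 3 differ is not broken down here. Compound 4 `O=C1COc2ccc(-c3cnc4ccccc4c3)cc2N1` has not yet been measured and differs from compound 3 by hydrogen in place of 4-fluorophenyl on an amide-type nitrogen in a ring, the same change, at the same place.

If the change carries over, the step is expected to be a 2.6-fold lower number from compound 3 to compound 4 (0.41 log units; beyond the scatter), resting on compound 1 and compound 2, where it gave an at least 2.5-fold lower number from compound 1 to compound 2 (0.40 log units; beyond the scatter). Compound 4 is therefore estimated at 15000 nM, expected to fall between 6000 nM and 40000 nM.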

Compound 4, half-maximal inhibitory concentration: > 40000 nM
Compound 4: only a limit was reported; the forecaster's own chance of this, stated with the estimate: 15%; at least 2.6-fold (0.42 log units) between middle value and limit.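

In this assay compound 4 gives > 40000 nM, which is a limit of the assay and not a number. Replacing the 4-fluorophenyl with hydrogen on the amide-type nitrogen gave an at least 1.0-fold higher number from compound 3 to compound 4 (0.01 log units; that floor lies within the scatter), so the lower number seen with the core of compound 1 did not appear on this second core. This does not show that the two cores truly respond differently, only that the comparison stays unsettled: the same change on two cores in this assay, an at least 2.5-fold lower number (0.40 log units; beyond the scatter) from compound 1 to compound 2 and an at least 1.0-fold higher number (0.01 log units; that floor lies within the scatter) from compound 3 to compound 4; the limit leaves it open whether they differ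

As far as these compounds go, what a methyl group or a longer chain ending in an amine would do on that nitrogen, on either core, stays open. Firmer comparisons would need values that can be read as numbers, and some of those shown cannot: the limit of > 40000 nM in this assay, at which 2 of the 4 values shown sit.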